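A few compounds are considered here, and "the series" means these few. Any claim that something is new, unique, unknown or untested is made for them only; others in the source may bear on it.

Compound 2 `Nc1cc(N)c2nc(-c3ccccc3)c(Sc3ccc(Cl)c(Cl)c3)nc2c1` carries the (3,4-dichlorophenyl)sulfanyl group on the shared core. In a functional assay on MCF7 cells (Homo sapiens) for inhibition, read by sulforhodamine B assay, with a stated time of 48 h (a higher number here means a weaker inhibitor of growth, a lower number a stronger inhibitor of growth), compound 2 gives 38000 nM, the only number shown for the series so far. Compound 1 `COc1ccc(Sc2nc3cc(N)cc(N)c3nc2-c2ccccc2)cc1` is its 4-methoxyphenyl counterpart on the sulfur. In this assay compound 1 gives < 100000 nM, which is a limit of the assay and not a number. Among the compounds with values here, the step that the limit leaves unreadable from compound 1 to compound 2 is thus not readable in size, and the limit of < 100000 nM in this assay, at which 1 of the 2 values shown sits, is the only evidence bearing on it. Compound 3 `Nc1cc(N)c2nc(-c3ccccc3)c(Oc3ccc(F)cc3)nc2c1` is the next member. Relative to compound 2 it has 4-fluorophenoxy in place of (3,4-dichlorophenyl)sulfanyl on an aromatic carbon. Within the data shown here, no measured step bears on this change; the one step recorded cannot be sized. No change beyond the scatter is therefore expected in this assay. For compound 3 the estimate is 40000 nM, with a range of 10000 nM to 100000 nM. The expected step of a 1.1-fold higher number from compound 2 to compound 3 (0.02 log units; within the scatter) is small.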

Compound 3, concentration for total growth inhibition: < 100000 nM
Compound 3: only a limit was reported (the forecaster's own chance of this, stated with the estimate: 35%); the middle value does not contradict the limit.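

Within the data shown here, no step can be read from compound 3 to compound 2 or to compound 1, since the only evidence bearing on them is a limit: the limit of < 100000 nM in this assay, at which 2 of the 3 values shown sit. In this assay the compounds shown leave open how 4-fluorophenoxy compares with either (3,4-dichlorophenyl)sulfanyl or (4-methoxyphenyl)sulfanyl on the shared core.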